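This account rests on a few compounds, and the source may have more. Where it says the series, first, only, none or still open, it means among the compounds named here.

Compound 1 `COC(=O)C1=C(C)N=C(SC)NC1c1cccc([N+](=O)[O-])c1` was tested in a functional assay (aorta) with Oryctolagus cuniculus as the target; on this read-out lower numbers stand for an effect already at smaller amounts and higher numbers for an effect only at larger amounts of compound. In this assay compound 1 gives only a limit, > 30000 nM. Compound 2 `COC(=O)C1=C(C)N=C(SC)NC1c1cc([N+](=O)[O-])ccc1SC` carries the change (methylsulfanyl in place of hydrogen on an aromatic carbon). In this assay compound 2 likewise gives only a limit, > 30000 nM. The step between them, a step that the two limits leave unreadable from compound 1 to compound 2, cannot be read, as both ends sit at the limit. Compound 3 `CSC1=NC(c2cccc([N+](=O)[O-])c2)C2=C(O)OCC2=N1` is built on a different core; how its core differs from that of compound 1 is not broken down here. In this assay compound 3 also gives only a limit, > 30000 nM. All three values thus share one feature, (the limit of > 30000 nM in this assay, at which 3 of the 3 values shown sit). Compound 4 `CSC1=NC(c2cccc([N+](=O)[O-])c2SC)C2=C(O)OCC2=N1` carries the change (methylsulfanyl in place of hydrogen on an aromatic carbon); this is the same kind of change as that from compound 1 to compound 2, but not the same, for in compound 4 the methylsulfanyl sits ortho to a nitro group, whereas in compound 2 it sits para to a nitro group. An expected step that the limit leaves unreadable from compound 3 to compound 4 rests on the earlier step that the two limits leave unreadable from compound 1 to compound 2, which with both values at the limit shows no movement at all. Compound 4 is accordingly estimated at 50000 nM, most likely again only a limit.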

Compound 4, half-maximal effective concentration: > 30000 nM
Compound 4 gave a limit, no number; the forecaster's own chance of this, stated with the estimate: 85%; the middle value does not contradict the limit.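

Among the compounds shown here, the step from compound 3 to compound 4 cannot be read, since both compounds give only a limit in this assay, so the result adds no new step. The compounds shown leave open whether methylsulfanyl in place of hydrogen on an aromatic carbon changes the effect at all, as all values share one feature: the limit of > 30000 nM in this assay, at which 4 of the 4 values shown sit.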